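Aryl urea series: chloro for trifluoromethyl on the terminal ring

A few compounds are considered here, and "the series" means these few. Any claim that something is new, unique, unknown or untested is made for them only; others in the source may bear on it.

Measured so far in a functional assay on ACHN cells (Homo sapiens) for inhibition, read by sulforhodamine B assay, with a stated time of 48 h; on this read-out higher numbers stand for weaker inhibition of growth and lower numbers for stronger inhibition of growth:
compound 1 `COc1cc2cc(Oc3ccc(NC(=O)Nc4cccc(C(F)(F)F)c4)cc3)c(C)nc2cc1OC` gives 1640 nM
compound 2 `COc1cc2cc(Oc3ccc(NC(=O)Nc4ccc(Cl)c(C(F)(F)F)c4)cc3)c(C)nc2cc1OC` gives 1070 nM

On these two numbers compound 2 stands lowest, with compound 1 nearest; that step, a 1.5-fold lower number from compound 1 to compound 2 (0.19 log units; within the scatter), is within the scatter. Compound 3 `COc1cc2cc(Oc3ccc(NC(=O)Nc4ccc(Cl)c(Cl)c4)cc3)c(C)nc2cc1OC` differs from compound 2 by chloro in place of trifluoromethyl on an aromatic carbon. Going by the values given here, no measured step bears on this exchange; the one known step, from compound 1 to compound 2, concerns a different position and stays within the scatter. The expected step in this assay is therefore none beyond the scatter, a 1.1-fold higher number from compound 2 to compound 3 (0.05 log units; within the scatter). Compound 3 is estimated at 1200 nM, range 500 nM to 3000 nM.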

Compound 3, concentration for 50% growth inhibition: 3000 nM
Beside the measured number, compound 3's estimate is 2.5-fold (0.40 log units) below it; low and high end bracket the measured number.
By their numbers in this assay, from the lowest: compounds 2, 1 and 3 (each within the scatter of the next, the first and the last beyond it).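

In this assay, going by these compounds alone, the exchange of trifluoromethyl for chloro on this aromatic carbon, ortho to a chloro group, gives the first step beyond the scatter, though a modest one (a 2.8-fold higher number from compound 2 to compound 3 (0.45 log units; beyond the scatter)). With 3,4-dichlorophenyl in place of 3-(trifluoromethyl)phenyl the step stays within the scatter (a 1.8-fold higher number from compound 1 to compound 3 (0.26 log units; within the scatter)), so the trifluoromethyl group counts here only with the chloro group present. No measurement on hand accounts for this step.

From the compounds shown here alone, whether a nitrile or an amine on this carbon would match trifluoromethyl remains open. Also open, going by these compounds, is whether the step holds with another group in place of the neighbouring chloro.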